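An Amide Substituent Change and Its Expected Effect

This account rests on a few compounds, and the source may have more. Where it says the series, first, only, none or still open, it means among the compounds named here.

Of the compounds shown here, three sharing one core have been tested in an assay on isolated protein for inhibition of histone deacetylase 8 (Homo sapiens), with a stated time of 1 h; a higher number here means a weaker inhibitor, a lower number a stronger inhibitor. Compound 1 `O=C(COc1ccc2cc(/C=C3/SC(=O)NC3=O)ccc2c1)Nc1cc(Cl)cc(C(F)(F)F)c1` carries a 3-chloro-5-(trifluoromethyl)phenyl group on its amide-type nitrogen. In this assay compound 1 gives > 50000 nM, which is a limit of the assay rather than a measured number, so compound 1 stands at the limit of > 50000 nM in this assay, at which 1 of the 3 values shown sits, and its true value is known only to lie beyond that point. Compound 2 `Cc1cccc(NC(=O)COc2ccc3cc(/C=C4/SC(=O)NC4=O)ccc3c2)n1` carries a 6-methylpyridin-2-yl group on the same nitrogen and gives 7500 nM. Compound 3 `Cc1cccc2sc(NC(=O)COc3ccc4cc(/C=C5/SC(=O)NC5=O)ccc4c3)nc12` carries a 4-methyl-1,3-benzothiazol-2-yl group and gives 5800 nM.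

Compound 4 `COc1ccc(NC(=O)COc2ccc3cc(/C=C4/SC(=O)NC4=O)ccc3c2)cc1` has not yet been measured. It differs from compound 1 in one place: 4-methoxyphenyl in place of 3-chloro-5-(trifluoromethyl)phenyl on an amide-type nitrogen. Within the data shown here, two measured steps bear on this change, as each also replaces the same group on the same nitrogen: an at least 6.6-fold lower number from compound 1 to compound 2 (0.82 log units; beyond the scatter) and an at least 8.6-fold lower number from compound 1 to compound 3 (0.93 log units; beyond the scatter). Between those two replacements the gap is small: a 1.3-fold lower number from compound 2 to compound 3 (0.11 log units; within the scatter). Each replacement of the 3-chloro-5-(trifluoromethyl)phenyl group gave a lower number, and a similar lowering is expected for compound 4, so a step of an at least 6.2-fold lower number from compound 1 to compound 4 (0.79 log units; beyond the scatter) is estimated. Compound 4 is thus expected to give 8000 nM in this assay, with a range from 2500 nM to 30000 nM.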

Compound 4, half-maximal inhibitory concentration: > 50000 nM
Compound 4 gave a limit, no number; the forecaster's own chance of this, stated with the estimate: 20%; at least 6.2-fold (0.79 log units) between middle value and limit.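

In this assay compound 4, like compound 1, gives a limit of the assay and not a number: the limit of > 50000 nM in this assay, at which 2 of the 4 values shown sit. Against the two compounds with measured numbers the change is clear, with an at least 8.6-fold higher number from compound 3 to compound 4 (0.93 log units; beyond the scatter) and an at least 6.6-fold higher number from compound 2 to compound 4 (0.82 log units; beyond the scatter), so the lowering seen earlier does not follow from simply removing the 3-chloro-5-(trifluoromethyl)phenyl group from the amide-type nitrogen. Among these four compounds, the two groups with one six-membered aromatic ring of carbon only, 3-chloro-5-(trifluoromethyl)phenyl and 4-methoxyphenyl, both end at the limit, whereas the 6-methylpyridin-2-yl and 4-methyl-1,3-benzothiazol-2-yl groups give measured numbers, and no compound shown goes against this.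

From the compounds shown here alone, the step from compound 1 to compound 4 cannot be read, so it remains unknown which of these two compounds is the stronger inhibitor, or whether they differ at all. Going by these compounds, it also remains open whether a phenyl ring carrying an amine or a carboxylic acid on this nitrogen would give a measured number, and whether a pyridin-2-yl group without its methyl would keep the number seen for compound 2.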